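A few compounds are considered here, and "the series" means these few. Any claim that something is new, unique, unknown or untested is made for them only; others in the source may bear on it.

Of the compounds shown here, three built on one shared core have been tested in a functional assay on the whole organism (strain albino) for inhibition, with Rattus norvegicus as the target, read by paw edema, with stated times of 30 min and 2 h, at a dose of 5 mg/kg by the oral route; a higher number here means more inhibition at the dose given (going by the name of the read-out), a lower number less inhibition. Compound 1 `CCOC(=O)Cc1n[nH]c(NC(=O)c2ccccc2)n1` gives 36.2% in this assay. Compound 2 `CCOC(=O)Cc1n[nH]c(NC(=O)c2ccc(Cl)cc2)n1` gives 39.1%, and compound 3 `CCOC(=O)Cc1n[nH]c(NC(=O)c2ccc(Br)cc2)n1` gives 40.4%. The steps between them are small: a number 2.9 percentage points higher from compound 1 to compound 2 (within the scatter), a number 4.2 percentage points higher from compound 1 to compound 3 (within the scatter) and a number 1.3 percentage points higher from compound 2 to compound 3 (within the scatter). Compound 3 thus carries the highest of the three numbers, but its gap to compound 2 and its gap to compound 1 both lie within the usual scatter, so the three compounds cannot be told apart on this evidence.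

Compound 4 `CCOC(=O)Cc1n[nH]c(NC(=O)c2ccc(OC)cc2)n1` differs from compound 3 by methoxy in place of bromo on an aromatic carbon. Among the measured compounds shown here, no measured step introduces a methoxy group; the steps that bear on the change are the three at the same place on the ring, and each of them stayed within the scatter. There is therefore no ground to expect a step beyond the scatter in this assay, in either direction, and compound 4 is estimated at 37%, with a range from 28% to 46%, which means an expected step of a number 3.4 percentage points lower from compound 3 to compound 4 (within the scatter).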

Compound 4, a percentage reported as inhibition, in the whole organism at one dose (the size of the read-out at that dose, not a potency): 38.2%
Compound 4: middle estimate off by 1.2 percentage points, on the low side; the range from low to high includes it.
By their numbers in this assay, from the lowest: compounds 1, 4, 2 and 3 (each within the scatter of the next).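

Methoxy, the only group here to carry a hydrogen-bond acceptor, gives a number 2.2 percentage points lower from compound 3 to compound 4 (within the scatter) and a number 0.9 percentage points lower from compound 2 to compound 4 (within the scatter) and a number 2 percentage points higher from compound 1 to compound 4 (within the scatter) in this assay when it sits on the aromatic carbon para to a large group. Hydrogen, chloro, bromo and methoxy at this place have now produced no step beyond the scatter, so replacing one heavy atom with two, one of them oxygen, does not separate compound 4 from the other three compounds. No measurement of any property of these groups is available to bear on this result.

The compounds shown leave open whether any group at this place, such as an amine, a carboxylic acid or a longer chain, would give a step beyond the scatter. They also leave open whether replacing the ethyl ester on the shared core would do so.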